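Replacing the hydroxyphenyl tail of a weak sulfamate inhibitor

This account rests on a few compounds, and the source may have more. Where it says the series, first, only, none or still open, it means among the compounds named here.

Compound 3 `CC(=O)NS(=O)(=O)O[C@@H]1[C@H](O)C[C@@H](O)C[C@H]1OCCCCc1ccccc1O` was examined in an assay on isolated protein for inhibition of inositol monophosphatase 1 (Bos taurus); a higher number here means a weaker inhibitor, a lower number a stronger inhibitor. In this assay compound 3 reaches only a limit, > 300000 nM. Compound 2 `NS(=O)(=O)O[C@@H]1[C@H](O)C[C@@H](O)C[C@H]1OCCCCc1ccccc1O` likewise reaches only a limit, > 300000 nM. Compound 1 `CC(C)OP(=O)(O)O[C@@H]1[C@H](O)C[C@@H](O)C[C@H]1OCCCCc1ccccc1O` gives 50000 nM, so the steps of an at least 6.0-fold higher number from compound 1 to compound 2 (0.77 log units; beyond the scatter) and an at least 6.0-fold higher number from compound 1 to compound 3 (0.77 log units; beyond the scatter) both end at the limit of > 300000 nM in this assay, at which 2 of the 3 values shown sit, while the step that the two limits leave unreadable from compound 2 to compound 3 cannot be read. Compound 4 `CC(=O)NS(=O)(=O)O[C@@H]1[C@H](O)C[C@@H](O)C[C@H]1OCCCCC1CCCCC1=O` differs from compound 3 by 2-oxocyclohexyl in place of 2-hydroxyphenyl on a saturated chain carbon, four bonds along the chain from an oxygen on a saturated carbon. Among the measured compounds shown here, none of the measured steps touches this part of the molecule, so no direct guide exists for the change. Compound 4 is expected to stay near the limit because compound 3 itself sits at the limit of > 300000 nM in this assay, at which 2 of the 3 values shown sit, giving an estimated step that the limit leaves unreadable from compound 3 to compound 4. The estimate for compound 4 is 500000 nM, with a range from 100000 nM to 3000000 nM.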

Compound 4, half-maximal inhibitory concentration: > 300000 nM
Compound 4 gave a limit, no number (the forecaster's own chance of this, stated with the estimate: 80%); the middle value is on the limit's open side.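

In this assay compound 4 reaches only a limit, > 300000 nM. Compound 3 also sits at a limit, so the step between these two compounds cannot be read. Going by these compounds, how 2-oxocyclohexyl compares with 2-hydroxyphenyl in strength of inhibition remains open.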